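The source may report more compounds than this note shows. Statements on the series, on what has been measured and on what is new or still open speak of the compounds shown alone.

Compound 2 `O=C(CSc1nccn1-c1cccc2ccccc12)Nc1ccccc1Cl` and compound 1 `O=C(CSc1nccn1-c1cccc2ccccc12)Nc1ccccc1F` share one core; compound 3 `Cc1ccc(-n2ccnc2SCC(=O)Nc2ccccc2Cl)cc1` carries another, and how the two cores differ is not broken down here. In an ADME assay on MT4 cells (Homo sapiens) for cytotoxicity, read by MTT assay (a higher number here means that more compound is tolerated, a lower number that less compound is tolerated), compound 2 gives 35200 nM and compound 1 gives 34700 nM; the change between them is fluoro in place of chloro on an aromatic carbon and it made a 1.0-fold lower number from compound 2 to compound 1 (0.01 log units; within the scatter). In this assay compound 3 gives 33700 nM, within the scatter of both other values. Compound 4 `Cc1ccc(-n2ccnc2SCC(=O)Nc2ccccc2F)cc1` is not yet measured; it arises from compound 3 by fluoro in place of chloro on an aromatic carbon, the same change carried onto the other core. For compound 4 a step of a 1.0-fold higher number from compound 3 to compound 4 (0.00 log units; within the scatter) is expected, because the earlier step of a 1.0-fold lower number from compound 2 to compound 1 (0.01 log units; within the scatter) lay within the scatter. Compound 4 is thus estimated at 34000 nM in this assay, with a likely range from 20000 nM to 55000 nM.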

Compound 4, half-maximal cytotoxic concentration: 37900 nM
Beside the measured number, compound 4's estimate is 1.1-fold (0.05 log units) below it; the range from low to high includes it.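

In this assay, fluoro in place of chloro on an aromatic carbon gives a 1.1-fold higher number from compound 3 to compound 4 (0.05 log units; within the scatter). Set beside the same change on the core of compound 1, the two steps do not differ: the same change on two cores in this assay, a 1.0-fold lower number (0.01 log units; within the scatter) from compound 2 to compound 1 and a 1.1-fold higher number (0.05 log units; within the scatter) from compound 3 to compound 4, 1.1-fold (0.06 log units) apart, within the scatter of two such steps. The 2-chlorophenyl to 2-fluorophenyl change thus has no readable effect on either core in this assay, but neither step leaves the scatter, so this does not show that a larger step would carry from one core to the other.

As far as these compounds go, it remains open whether other groups in place of the chloro or fluoro, such as a methoxy group or an amine, would behave alike on both cores. Cores beyond these two also remain untested here.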